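Propoxycarbonyl to benzyloxycarbonyl: working notes

The source may hold more compounds than are shown below. What is called first, only, known or untested is meant among the compounds shown, and "the series" means these compounds.

Measured in a functional assay on MDA-MB-231 cells (Homo sapiens) for antiproliferative activity, read by MTT assay, with a stated time of 48 h; on this read-out higher numbers stand for weaker inhibition of growth and lower numbers for stronger inhibition of growth:
- compound 1 `CCOC(=O)N1N=C(c2ccc(OC)cc2)CC1c1cc(OC)c(OC)c(OC)c1`: 2660 nM
- compound 2 `CCCOC(=O)N1N=C(c2ccc(OC)cc2)CC1c1cc(OC)c(OC)c(OC)c1`: 20400 nM

Compound 2, at 20400 nM, holds the higher of the two numbers. Compound 3 `COc1ccc(C2=NN(C(=O)OCc3ccccc3)C(c3cc(OC)c(OC)c(OC)c3)C2)cc1` differs from it by phenyl in place of ethyl on a saturated chain carbon bound to an oxygen next to a carbonyl group. For the measured compounds named here, only one measured step bears on this change, the modest 7.7-fold higher number from compound 1 to compound 2 (0.88 log units; beyond the scatter), and it involves no ring. On that single step, no change beyond the scatter is expected in this assay, though with wide uncertainty. The expected step is a 1.4-fold lower number from compound 2 to compound 3 (0.13 log units; within the scatter). Compound 3 is estimated at 15000 nM, within a range of 3000 nM to 60000 nM.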

Compound 3, concentration for 50% growth inhibition: > 10000 nM
Compound 3 gave a limit, no number; the forecaster's own chance of this, stated with the estimate: 5%; the middle value does not contradict the limit.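

Compound 3 gives a limit, not a number, in this assay: the limit of > 10000 nM in this assay, at which 1 of the 3 values shown sits. Even so, phenyl in place of methyl at this place still gives an at least 3.7-fold higher number from compound 1 to compound 3 (0.57 log units; beyond the scatter), so a six-membered aromatic ring, like the propyl of compound 2, leaves growth inhibition weaker than with compound 1. The step between propyl and benzyl cannot be read, so these two groups cannot be ordered. From the compounds shown here alone, whether a longer chain, or an amine or a carboxylic acid carried on this chain, would also weaken growth inhibition remains open.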